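Removing the methoxy from an inactive dichloro analogue

This account rests on a few compounds, and the source may have more. Where it says the series, first, only, none or still open, it means among the compounds named here.

Compound 2 `C=CCn1c(=O)/c(=C\c2ccc(Cl)c(Cl)c2)[nH]c(=O)/c1=C\c1ccccc1OC` was examined in a functional assay on K562 cells (Homo sapiens) for cytotoxicity, read by CCK-8 assay, with a stated time of 72 h (on this read-out higher numbers stand for weaker inhibition and lower numbers for stronger inhibition), and gave "not active" (no number reported), with no number given. Its nearest relatives do give numbers: compound 1 `C=CCn1c(=O)/c(=C\c2cccc(Cl)c2)[nH]c(=O)/c1=C\c1ccccc1OC` gives 2700 nM in this assay, and compound 3 `C=CCn1c(=O)/c(=C\c2ccccc2C(F)(F)F)[nH]c(=O)/c1=C\c1ccccc1OC` gives 2700 nM. Within the data shown here, the one step measured between them, no change at the digits printed from compound 1 to compound 3 (within the scatter), shows that exchanging one aryl group for another on the double-bonded chain carbon left the read-out unchanged within the scatter. Compound 4 `C=CCn1c(=O)/c(=C\c2ccc(Cl)c(Cl)c2)[nH]c(=O)/c1=C\c1ccccc1` differs from compound 2 by hydrogen in place of methoxy on an aromatic carbon. Among the measured compounds shown here, no measured step touches the methoxy itself; the only step available concerns the other aryl group and was flat. For the measured compounds named here, compound 2 stands outside the range in which a number was reported, and nothing among the measured compounds suggests that taking the methoxy away would bring a compound back into that range. The expectation for compound 4 is therefore a weak result in this assay, most probably once more without a number, and should a number be obtained it is estimated at about 12000 nM, with an expected range from 3000 nM to 50000 nM.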

Compound 4, half-maximal inhibitory concentration: "not active" (no number reported)
The entry for compound 4 holds no number, so the estimate cannot be set against anything.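

In this assay compound 2 and compound 4 are both reported as not active, without a number, so no step can be read between them. From the compounds shown here alone, the effect of going from 2-methoxyphenyl to phenyl on this read-out stays open, as does how far either compound lies from the reported range. Nothing shown bears on a cause for this result.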